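The source may hold more compounds than are shown below. What is called first, only, known or untested is meant among the compounds shown, and "the series" means these compounds.

Compound 1, `CCCCCCNc1nc(SCc2ccc(C(F)(F)F)cc2)nc2ccccc12`, gives 24300 nM in a functional assay on MCF7 cells (Homo sapiens) for cytotoxicity, read by MTT assay, with a stated time of 72 h; a lower number here means a stronger inhibitor, a higher number a weaker inhibitor.
Compound 2, `FC(F)(F)c1ccc(CSc2nc(Nc3ccccc3Cl)c3ccccc3n2)cc1`, reaches only the assay limit of > 50000 nM in this assay, so no number is known for it.
Compound 3, `Cc1ccccc1Nc1nc(SCc2ccc(C(F)(F)F)cc2)nc2ccccc12`, gives 37500 nM in this assay.

The three compounds share one core and differ only in the group on the nitrogen on the aromatic ring. Compound 1 carries hexyl there and shows the lower of the two actual numbers, but it is not separated from compound 3 beyond the scatter, since a 1.5-fold higher number from compound 1 to compound 3 (0.19 log units; within the scatter). The third value is a limit (the limit of > 50000 nM in this assay, at which 1 of the 3 values shown sits), and from compound 1 to the chlorinated compound there is an at least 2.0-fold higher number from compound 1 to compound 2 (0.31 log units; beyond the scatter). Between the two aryl compounds there is an at least 1.3-fold lower number from compound 2 to compound 3 (0.12 log units; that floor lies within the scatter).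

Compound 4, `COc1ccc(Nc2nc(SCc3ccc(C(F)(F)F)cc3)nc3ccccc23)cc1`, has not yet been measured in this assay. It differs from compound 1 as follows: 4-methoxyphenyl in place of hexyl on a nitrogen on an aromatic ring. The two measured steps from compound 1 bear directly on it, because an at least 2.0-fold higher number from compound 1 to compound 2 (0.31 log units; beyond the scatter) and a 1.5-fold higher number from compound 1 to compound 3 (0.19 log units; within the scatter) both swap hexyl for an aryl group on that nitrogen, and both moved the number up, one within and one beyond the scatter. A step of similar kind is therefore expected here, upward and modest: a 1.4-fold higher number from compound 1 to compound 4 (0.16 log units; within the scatter). Compound 4 is thus estimated at 35000 nM in this assay, within a range of 15000 nM to 80000 nM.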

Compound 4, half-maximal inhibitory concentration: 47200 nM
Compound 4: the middle estimate sits 1.3-fold (0.13 log units) below what was measured; the measured number falls inside the stated range.
By their numbers in this assay, from the lowest: compounds 1, 3 and 4 (each within the scatter of the next). At a limit, above all of these: compound 2.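

Going by these compounds alone, putting 4-methoxyphenyl on this nitrogen brings an oxygen and a hydrogen-bond acceptor to the place, yet it does not separate compound 4 from the earlier compounds with actual numbers: there is a 1.9-fold higher number from compound 1 to compound 4 (0.29 log units; within the scatter), and there is a 1.3-fold higher number from compound 3 to compound 4 (0.10 log units; within the scatter). In this assay, within the data shown here, neither of the two aryl groups with actual numbers, 2-methylphenyl and 4-methoxyphenyl, now stands beyond the scatter from hexyl, and only the step to the 2-chlorophenyl compound does so. Against that compound the comparison gives only an at least 1.0-fold lower number from compound 2 to compound 4 (0.02 log units; that floor lies within the scatter), and compound 2 stands at a limit, not a number: the limit of > 50000 nM in this assay, at which 1 of the 4 values shown sits.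

The compounds shown leave open how a shorter chain such as butyl, a benzyl group or a chain ending in a dimethylamine would read on this nitrogen, and whether a free aniline-type amino group or a carboxylic acid on the aryl ring would change the number. They also say nothing about the other end of the molecule, since all four compounds keep the same 4-(trifluoromethyl)benzyl group on sulfur.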